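Aryl imine to anilino hydrazone step on shared core

The compounds below may be only part of what the source reports. "The series", "measured", "known", "first", "only" and "open" are said of these compounds alone.

Measured so far in a functional assay, read by spectrophotometry, with a stated time of 1 h; on this read-out lower numbers stand for stronger inhibition and higher numbers for weaker inhibition:
compound 1, `O=c1cc(/C=N\c2ccccc2O)c2c(OCc3ccccc3)cc(OCc3ccccc3)cc2o1`, gives 348000 nM
compound 2, `O=c1cc(/C=N\c2ccc(O)cc2)c2ccc(OCc3ccccc3)cc2o1`, gives 233000 nM
compound 3, `O=c1cc(/C=N\Nc2ccc([N+](=O)[O-])cc2[N+](=O)[O-])c2ccc(OCc3ccccc3)cc2o1`, gives 1970000 nM

Compound 2 and compound 1 lie within the scatter of each other in this assay; compound 3 stands well beyond both. Compound 4, `O=c1cc(/C=N\Nc2ccccc2)c2ccc(OCc3ccccc3)cc2o1`, is not yet measured; it differs from compound 2 by anilino in place of 4-hydroxyphenyl on a double-bonded nitrogen. For the measured compounds named here, no step between measured compounds isolates this change, and compound 3, the one measured hydrazone, carries a different aryl group, so it offers no direct guide. A modest step toward weaker inhibition is expected, a 1.7-fold higher number from compound 2 to compound 4 (0.23 log units; within the scatter), not clearly beyond the scatter. Compound 4 is expected to give 400000 nM in this assay, in a range of 150000 nM to 1200000 nM.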

Compound 4, half-maximal inhibitory concentration: 455000 nM
Compound 4: the middle estimate sits 1.1-fold (0.06 log units) below what was measured; the measured number falls inside the stated range.
By their numbers in this assay, from the lowest: compounds 2, 1 and 4 (each within the scatter of the next); then compound 3.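

In this assay, for the compounds shown here, anilino in place of 4-hydroxyphenyl on a double-bonded nitrogen gives a 2.0-fold higher number from compound 2 to compound 4 (0.29 log units; within the scatter), the only step that isolates a single change. At this position, on the shared core, the two groups therefore cannot be told apart in this read-out, and the hydroxyl on the aromatic ring of compound 2 is not shown to be needed. No measurement available here explains this result.

Still open, as far as these compounds go, is whether an amine or a carboxylic acid on the anilino ring would move the number beyond the scatter. A methyl on the anilino nitrogen is equally untested in the compounds shown.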